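Bromo to fluoro exchange in two aryl triazole esters

The compounds below may be only part of what the source reports. "The series", "measured", "known", "first", "only" and "open" are said of these compounds alone.

Compound 1 `CS(=O)(=O)c1ccc(-c2nc(SCCCOC(=O)/C=C/c3ccc(O)c(O)c3)nn2-c2ccc(Br)cc2)cc1` was tested in a functional assay on Caco-2 cells (Homo sapiens) for antiproliferative activity, read by MTT assay, with a stated time of 72 h (on this read-out higher numbers stand for weaker inhibition and lower numbers for stronger inhibition), where compound 1 gives 12400 nM. Compound 2 `CS(=O)(=O)c1ccc(-c2nc(SCCCOC(=O)/C=C/c3ccc(O)c(O)c3)nn2-c2ccc(F)cc2)cc1` differs from it by fluoro in place of bromo on an aromatic carbon; in this assay compound 2 gives 11200 nM, a step of a 1.1-fold lower number from compound 1 to compound 2 (0.04 log units; within the scatter). Compound 3 `COc1cc(/C=C/C(=O)OCCSc2nc(-c3ccc(S(C)(=O)=O)cc3)n(-c3ccc(Br)cc3)n2)ccc1OC(C)=O` carries a different core, and the difference between the two cores is not broken down here. In this assay compound 3 gives 12100 nM, close to the numbers of compound 1 and compound 2. Compound 4 `COc1cc(/C=C/C(=O)OCCSc2nc(-c3ccc(S(C)(=O)=O)cc3)n(-c3ccc(F)cc3)n2)ccc1OC(C)=O` has not been measured and differs from compound 3 by fluoro in place of bromo on an aromatic carbon, the same change made once before. Because the step of a 1.1-fold lower number from compound 1 to compound 2 (0.04 log units; within the scatter) stayed within the scatter, a like step is expected here, a 1.1-fold lower number from compound 3 to compound 4 (0.04 log units; within the scatter). On that basis compound 4 is estimated at 11000 nM, expected to fall between 6000 nM and 22000 nM.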

Compound 4, half-maximal inhibitory concentration: 10800 nM
Compound 4: the middle estimate sits 1.0-fold (0.01 log units) above what was measured, and the stated range covers the measured number.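

In this assay, the exchange of 4-bromophenyl to 4-fluorophenyl gives a 1.1-fold lower number from compound 3 to compound 4 (0.05 log units; within the scatter). Set beside the earlier step, the second one agrees with it: the same change on two cores in this assay, a 1.1-fold lower number (0.04 log units; within the scatter) from compound 1 to compound 2 and a 1.1-fold lower number (0.05 log units; within the scatter) from compound 3 to compound 4, 1.0-fold (0.01 log units) apart, within the scatter of two such steps Both steps lie within the scatter, so the two pairs show that this exchange leaves the number essentially unmoved on both cores, but they do not show an effect of measurable size being carried across, nor do they speak for any core beyond these two.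

Still open, going by these compounds, is whether an amine, a carboxylic acid or a nitrile on the same aromatic carbon would move the number beyond the scatter. Also open, on these data alone, is how a longer chain between the sulfur and the ester would read on either core.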